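Dropping the methoxy group: from compound 3 to compound 4

A few compounds are considered here, and "the series" means these few. Any claim that something is new, unique, unknown or untested is made for them only; others in the source may bear on it.

Measured so far in a functional assay on HeLa cells (Homo sapiens) for inhibition, read by CCK-8 assay, with a stated time of 48 h; on this read-out higher numbers stand for weaker inhibition and lower numbers for stronger inhibition:
compound 1 `COc1ccc(-c2cc3nccc(-c4cc(OC)c(OC)c(OC)c4)n3n2)cc1[N+](=O)[O-]`: > 10000 nM.
compound 2 `COc1cc(-c2cc3nccc(-c4c[nH]c5ccccc45)n3n2)cc(OC)c1OC`: > 10000 nM.
compound 3 `COc1ccc(-c2cc3nccc(-c4cc(OC)c(OC)c(OC)c4)n3n2)cc1F`: 236 nM.

The value of compound 1 is a limit of this assay, not a number. The value of compound 2 is likewise a limit. Compound 3 gives the only number shown, the limit of > 10000 nM in this assay, at which 2 of the 3 values shown sit, holding the other two. For the measured compounds named here, the one measured step, an at least 42-fold lower number from compound 1 to compound 3 (1.62 log units; beyond the scatter), is large. Compound 4 `COc1cc(-c2ccnc3cc(-c4ccc(F)cc4)nn23)cc(OC)c1OC` differs from compound 3 by 4-fluorophenyl in place of 3-fluoro-4-methoxyphenyl on an aromatic carbon. Going by the values given here, no measured step concerns this change, since the only step swaps fluoro for nitro. A modest weakening is therefore expected, a 2.5-fold higher number from compound 3 to compound 4 (0.41 log units; beyond the scatter), and compound 4 is estimated at 600 nM, within 150 nM to 3000 nM in this assay.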

Compound 4, half-maximal inhibitory concentration: 5840 nM
The estimate for compound 4 lay 9.7-fold (0.99 log units) below the measured number; the whole stated range lies below it.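

In this assay, replacing 3-fluoro-4-methoxyphenyl with 4-fluorophenyl gives a 25-fold higher number from compound 3 to compound 4 (1.39 log units; beyond the scatter), a large change. The earlier step showed only that fluoro gave a far lower number than nitro, whereas this one shows that keeping a fluoro on this phenyl ring does not by itself preserve the low number. Nothing measured here explains the loss. The methoxy group left and the fluoro changed place in the same step, so their shares cannot be separated. From the compounds shown here alone, whether an amine or a hydroxyl in place of that methoxy group would keep the number low also stays open.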